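From dimethylamino to amino: solubility notes

This account rests on a few compounds, and the source may have more. Where it says the series, first, only, none or still open, it means among the compounds named here.

In a physicochemical assay for solubility, read by LC-MS, in phosphate buffer, with a stated time of 24 h, at pH 7.4 (a lower number here means a less soluble compound, a higher number a more soluble compound), compound 1 `CCN(CCN)c1ccc(Nc2cc(NC3CC3)n3ncc(C#N)c3n2)cc1NC(C)=O` gives > 1000000 nM, which is a limit of the assay. Compound 2 `CC(=O)Nc1cc(Nc2cc(NC3CC3)n3ncc(C#N)c3n2)ccc1N1CC[C@H](N(C)C)C1` gives > 800000 nM, also a limit, so compound 2 stands without a true number. Compound 3 `CC(=O)Nc1cc(Nc2cc(NC3CC3)n3ncc(C#N)c3n2)ccc1N1CC[C@H](N)C1` carries amino in place of dimethylamino on a saturated ring carbon. Among the measured compounds shown here, the only measured step, a step that the two limits leave unreadable from compound 1 to compound 2, offers no size to carry over, so no change beyond the scatter is expected in this assay. The expected result is a number no higher from compound 2 to compound 3 (the limit leaves the size open). Compound 3 is estimated at 800000 nM, with an expected range of 300000 nM to 2000000 nM.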

Compound 3, solubility: 590000 nM
The estimate for compound 3 lay 1.4-fold (0.13 log units) above the measured number, and the stated range covers the measured number.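

In this assay compound 3 gives 590000 nM, the first true number among the compounds shown. The change from 3-(dimethylamino)pyrrolidin-1-yl to 3-aminopyrrolidin-1-yl reads as an at least 1.3-fold lower number from compound 2 to compound 3 (0.13 log units; that floor lies within the scatter), and the ring-bearing group in place of the open chain on the aromatic carbon reads as an at least 1.6-fold lower number from compound 1 to compound 3 (0.22 log units; that floor lies within the scatter). On these data alone, both are floors set by limits, so their true sizes stay open, and the step between compound 1 and compound 2 cannot be read.

As far as these compounds go, how a hydroxyl or a carboxylic acid in place of amino on the saturated ring carbon would read remains open.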